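Swapping 2-fluorophenyl for 2,4-dimethylphenyl on the shared core

The source may hold more compounds than are shown below. What is called first, only, known or untested is meant among the compounds shown, and "the series" means these compounds.

In a functional assay on HL-60 cells (Homo sapiens) for antiproliferative activity, read by MTT assay, with a stated time of 24 h (a higher number here means a weaker inhibitor, a lower number a stronger inhibitor), compound 2 (`CNC(=O)c1ccccc1Oc1nc(Nc2ccccc2F)ncc1Br`) gives > 50000 nM as its reading, which is a limit and not a number. So compound 2 has only this standing (the limit of > 50000 nM in this assay, at which 1 of the 3 values shown sits). Compound 1 (`CNC(=O)c1ccccc1Oc1nc(Nc2ccc(Br)cc2)ncc1Br`) gives 39700 nM and compound 3 (`CNC(=O)c1ccccc1Oc1nc(Nc2cccc(Br)c2)ncc1Br`) gives 38700 nM as their readings, with a 1.0-fold lower number from compound 1 to compound 3 (0.01 log units; within the scatter) as the step. One further step bears on the change, an at least 1.2-fold higher number from compound 1 to compound 2 (0.10 log units; that floor lies within the scatter), whose floor stays within the scatter. Compound 4 (`CNC(=O)c1ccccc1Oc1nc(Nc2ccc(C)cc2C)ncc1Br`) carries 2,4-dimethylphenyl in place of 2-fluorophenyl on a nitrogen on an aromatic ring. Among the compounds with values here, no measured compound holds the new group, and with an at least 1.2-fold lower number from compound 2 to compound 3 (0.11 log units; that floor lies within the scatter) as the other step for compound 2, no step beyond the scatter is expected in this assay in either direction. The expected step is an at least 1.1-fold lower number from compound 2 to compound 4 (0.04 log units; that floor lies within the scatter) on this estimate. For compound 4 the estimated value is 45000 nM within an expected range from 25000 nM to 80000 nM overall.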

Compound 4, half-maximal inhibitory concentration: 32300 nM
Compound 4: middle estimate off by 1.4-fold (0.14 log units), on the high side, within the range that was stated.
By their numbers in this assay, from the lowest: compounds 4, 3 and 1 (each within the scatter of the next). At a limit, above all of these: compound 2.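

In this assay the 2,4-dimethylphenyl group on this nitrogen gives a real number where 2-fluorophenyl gave none, yet the floor of that step does not clear the scatter (an at least 1.5-fold lower number from compound 2 to compound 4 (0.18 log units; that floor lies within the scatter)). The new group also stays within the scatter of both bromophenyl groups (a 1.2-fold lower number from compound 3 to compound 4 (0.08 log units; within the scatter); a 1.2-fold lower number from compound 1 to compound 4 (0.09 log units; within the scatter)), so this change opens no real gap among the compounds with numbers. From the compounds shown here alone, compound 2 has a limit and not a number, so the true size of its step stays unknown: the limit of > 50000 nM in this assay, at which 1 of the 4 values shown sits.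

Going by these compounds, whether an amine or a carboxylic acid on this phenyl ring, or a longer chain in its place, would move the reading beyond the scatter stays open.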